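Removing the core methyl: from compound 2 to compound 3

This account rests on a few compounds, and the source may have more. Where it says the series, first, only, none or still open, it means among the compounds named here.

Measured compounds:
compound 1 `C=CC(=O)Nc1cc(Nc2ncc(Cl)c(Nc3ccccc3S(=O)(=O)C(C)C)n2)c(OC)cc1N1CCCCC1` gives 29 nM
compound 2 `C=CC(=O)Nc1cc(Nc2ncc(C)c(Nc3ccccc3S(=O)(=O)C(C)C)n2)c(OC)cc1N1CCN(CC)CC1` gives 2 nM

Both numbers come from a functional assay on NCI-H3122 cells (Homo sapiens) for inhibition, read by CellTiter-Glo, with a stated time of 72 h; a lower number here means a stronger inhibitor of growth, a higher number a weaker inhibitor of growth. Compound 2 stands lowest of the two; its nearest neighbour, compound 1, gives a number higher by a margin beyond the scatter. Among the compounds with values here, the two compounds differ in more than one place, so their gap cannot be assigned to any single change; the pair shows only that compound 2 sits well below compound 1.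

Compound 3 `C=CC(=O)Nc1cc(Nc2nccc(Nc3ccccc3S(=O)(=O)C(C)C)n2)c(OC)cc1N1CCN(CC)CC1` differs from compound 2 by hydrogen in place of methyl on an aromatic carbon. Within the data shown here, no measured pair isolates this change, and neither measured compound shows that position bare, so the direction of the step cannot be read from the data. A modest loss of growth inhibition is expected rather than none. Compound 3 is therefore expected to give 6 nM, with a range from 2 nM to 20 nM. The estimate implies an expected step of a 3.0-fold higher number from compound 2 to compound 3 (0.48 log units; beyond the scatter), toward weaker inhibition and probably close to the edge of the scatter.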

Compound 3, concentration for 50% growth inhibition: 41 nM
For compound 3 the middle estimate is 6.8-fold (0.83 log units) below the measured one, outside the stated range (above it).
By their numbers in this assay, from the lowest: compound 2; then compounds 1 and 3 (each within the scatter of the next).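

Replacing methyl with hydrogen on this aromatic carbon, two atoms from the ring nitrogen, gives in this assay a 21-fold higher number from compound 2 to compound 3 (1.31 log units; beyond the scatter), a large step toward weaker inhibition of growth. Within the data shown here, this is the first comparison that isolates a single place, and it shows that the loss of one carbon atom at this position is enough to weaken growth inhibition well beyond the scatter. Nothing available explains the size of this step.

Only methyl and hydrogen can be compared directly here. Compound 1 carries chlorine on this carbon but also differs from compound 2 elsewhere. From the compounds shown here alone, it remains open whether a longer chain such as ethyl, or a methoxy group, at this position would hold the growth inhibition of compound 2, and whether a chlorine would do so with the ethylpiperazine kept in place.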